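The source may report more compounds than this note shows. Statements on the series, on what has been measured and on what is new or still open speak of the compounds shown alone.

Series in a functional assay on L1210 cells (Mus musculus) for inhibition; on this read-out lower numbers stand for stronger inhibition and higher numbers for weaker inhibition:

- compound 1 `O=c1ccn(COCCO)c(=O)[nH]1`: compound 1 gives > 1000 ug/mL, a limit of the assay and not a number.
- compound 2 `Cc1cn(COCCO)c(=O)[nH]c1=O`: compound 2 gives > 1000 ug/mL, a limit of the assay and not a number.
- compound 3 `O=c1[nH]c(=O)n(COCCO)cc1[N+](=O)[O-]`: compound 3 gives > 1000 ug/mL, a limit of the assay and not a number.

Compound 3 therefore stands nowhere in particular on the numbers shown: all three values sit at one and the same limit, (the limit of > 1000 ug/mL in this assay, at which 3 of the 3 values shown sit). The steps within the measured set, a step that the two limits leave unreadable from compound 1 to compound 2, a step that the two limits leave unreadable from compound 1 to compound 3 and a step that the two limits leave unreadable from compound 2 to compound 3, are all unreadable, so the measured set carries no information on the size of any step in this assay.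

Compound 4 `O=c1[nH]c(=O)n(COCCO)cc1/C=C/Br` is the next compound. Compared with compound 3 the change is 2-bromoethenyl in place of nitro on an aromatic carbon. Going by the values given here, no measured step bears on a 2-bromoethenyl group; the only steps on this aromatic carbon, methyl or nitro in place of hydrogen and nitro in place of methyl, gave nothing readable. Direction and size of the step in this assay are thus unknown from the data, and the most likely outcome is another limit. Compound 4 is estimated at 1000 ug/mL, with a range of 300 ug/mL to 3000 ug/mL. The step this estimate implies, a number no higher from compound 3 to compound 4 (the limit leaves the size open), is an expectation only, not a reading from the series.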

Compound 4, concentration for 50% inhibition: > 1000 ug/mL
Compound 4 was reported as a limit; the forecaster's own chance of this, stated with the estimate: 60%; the middle value sits exactly at the limit.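

In this assay compound 4 gives > 1000 ug/mL as a limit of the assay and not a number, so its steps from compound 1, compound 2 and compound 3 cannot be read. The compounds shown leave open the size of any change on this aromatic carbon, since every value sits at one limit: the limit of > 1000 ug/mL in this assay, at which 4 of the 4 values shown sit.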